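A few compounds are considered here, and "the series" means these few. Any claim that something is new, unique, unknown or untested is made for them only; others in the source may bear on it.

Measured compounds:
- compound 1, `O=C(Nc1ccc2[nH]nnc2c1)[C@H]1CCCN1C(=O)C1(c2cccc(Cl)c2)CCCC1`, 20 nM
- compound 2, `CNC(=O)c1cccc(NC(=O)[C@H]2CCCN2C(=O)C2(c3cccc(Cl)c3)CCCC2)c1`, 1260 nM
- compound 3, `O=C(Nc1ccc2[nH]ncc2c1)[C@H]1CCCN1C(=O)C1(c2cccc(Cl)c2)CCCC1`, 1 nM

In an assay on isolated protein for inhibition of histone acetyltransferase p300 (Homo sapiens), with a stated time of 60 min (a lower number here means a stronger inhibitor, a higher number a weaker inhibitor), compound 3 gives the lowest number of the three. Its nearest neighbour is compound 1, shown by a 20-fold lower number from compound 1 to compound 3 (1.30 log units; beyond the scatter), and its furthest is compound 2, shown by a 1300-fold lower number from compound 2 to compound 3 (3.10 log units; beyond the scatter); both of these are large steps beyond the scatter. The next compound, compound 4 with structure `O=C(Nc1ccc2[nH]ccc2n1)[C@H]1CCCN1C(=O)C1(c2cccc(Cl)c2)CCCC1`, has not yet been measured. The change from compound 3 to compound 4 is a group of 9 heavy atoms (7 carbon, 2 nitrogen; one five-membered aromatic ring with 1 hetero atom, one six-membered aromatic ring with 1 hetero atom) in place of a group of 9 heavy atoms (7 carbon, 2 nitrogen; one five-membered aromatic ring with 2 hetero atoms, one six-membered aromatic ring of carbon only), on an amide-type nitrogen.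

Within the data shown here, the steps that bear on this are those in which the group on the amide-type nitrogen was exchanged: a 20-fold lower number from compound 1 to compound 3 (1.30 log units; beyond the scatter) and a 63-fold higher number from compound 1 to compound 2 (1.80 log units; beyond the scatter), both large. They show that this assay responds strongly to what sits on that nitrogen, even when a bicyclic aromatic group is kept and only ring nitrogens are rearranged. The change into compound 4 also keeps the bicyclic arrangement and the single hydrogen-bond donor and acceptor, so a step smaller than those between the measured compounds, in the direction of a higher number, is expected. Compound 4 is therefore estimated at 10 nM, within 2 nM to 60 nM, corresponding to an expected 10-fold higher number from compound 3 to compound 4 (1.00 log units; beyond the scatter).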

Compound 4, half-maximal inhibitory concentration: 0.159 nM
Compound 4: middle estimate off by 63-fold (1.80 log units), on the high side, outside the stated range (below it).
By their numbers in this assay, from the lowest: compound 4; then compound 3; then compound 1; then compound 2.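

In this assay the exchange of 1H-indazol-5-yl for the group with one hetero atom in each of its two rings, on the amide-type nitrogen, gives a 6.3-fold lower number from compound 3 to compound 4 (0.80 log units; beyond the scatter) as a modest step, even though the two groups have the same atoms and the same counts of hydrogen-bond donors and acceptors, so how those atoms are joined is enough on its own to move the number at this position. The earlier compounds had shown large steps at this nitrogen, but the new group extends the range further, with a 130-fold lower number from compound 1 to compound 4 (2.10 log units; beyond the scatter) and a 7900-fold lower number from compound 2 to compound 4 (3.90 log units; beyond the scatter) as large steps, which makes compound 4 the strongest inhibitor of the four. Nothing given here accounts for these steps.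

The compounds shown do not separate the effect of the hetero atom in the six-membered ring from that of the one taken out of the five-membered ring, a question that 1H-indol-5-yl on the same nitrogen could address. They also leave open whether the new group tolerates an added substituent, such as a methyl group or an amine, and how any such change would read in this assay for the shared core.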